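Ring-opened carboxylic acid analogue of a leukotriene receptor ligand

The source may hold more compounds than are shown below. What is called first, only, known or untested is meant among the compounds shown, and "the series" means these compounds.

Measured so far:
compound 1 `CC(CCc1ccc(OCc2ccc3ccccc3n2)cc1)Cc1nnn[nH]1` gives 25 nM
compound 2 `O=C(O)CCC(Cc1ccc(OCc2ccc3ccccc3n2)cc1)c1ccccc1` gives 31 nM
compound 3 `O=C(O)CC1CCC(c2ccc(OCc3ccc4ccccc4n3)cc2)C1` gives 22 nM

All three were tested in an assay on membranes from lung (Cavia porcellus) for binding affinity to cysteinyl leukotriene receptor (Homo sapiens); on this read-out higher numbers stand for weaker inhibition and lower numbers for stronger inhibition. Compound 3 shows the lowest of the three numbers, but compound 1 and compound 2 lie within the usual scatter of it, so no order among them can be read from these values. The next compound, compound 4 `CC(CCC(=O)O)Cc1ccc(OCc2ccc3ccccc3n2)cc1`, keeps the shared core and changes the acid-bearing side chain: 4-carboxy-2-methylbutyl in place of 3-(carboxymethyl)cyclopentyl on an aromatic carbon. For the measured compounds named here, no measured pair shows this exact change, so there is no directly comparable step to lean on. Because compound 1 gives 25 nM with a flexible chain of similar length on the same aromatic carbon, and compound 3 gives 22 nM, no step beyond the scatter is expected for compound 4; the estimate is a 1.4-fold higher number from compound 3 to compound 4 (0.13 log units; within the scatter). Compound 4 is therefore expected to give about 30 nM, likely between 10 nM and 90 nM.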

Compound 4, inhibition constant: 43 nM
Compound 4: the middle estimate sits 1.4-fold (0.16 log units) below what was measured; the range from low to high includes it.
By their numbers in this assay, from the lowest: compounds 3, 1, 2 and 4 (each within the scatter of the next).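

In this assay, replacing the ring of 3-(carboxymethyl)cyclopentyl with the open chain 4-carboxy-2-methylbutyl gives a 2.0-fold higher number from compound 3 to compound 4 (0.29 log units; within the scatter) and so shows that, at this position on the aromatic carbon, losing the five-membered ring brings no step beyond the scatter. Methyl in place of phenyl on the chain gives a 1.4-fold higher number from compound 2 to compound 4 (0.14 log units; within the scatter) and 3-carboxy-1-methylpropyl in place of 2-((1H-tetrazol-5-yl)methyl)propyl gives a 1.7-fold higher number from compound 1 to compound 4 (0.24 log units; within the scatter) and neither of these stands out from the scatter either. Going by these compounds, what an amine in place of the carboxylic acid, or a longer chain, would give remains open. Nothing available offers a reason for these results.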